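Swapping Chloro for Sulfamoyl: What to Expect

The source may report more compounds than this note shows. Statements on the series, on what has been measured and on what is new or still open speak of the compounds shown alone.

Compound 2 `COc1ccc(C(=O)C(CC(=O)c2ccc(Cl)cc2)c2cn(-c3ccc(Cl)cc3)nc2-c2ccc(OC)cc2)cc1` is one of two compounds tested in a functional assay on the whole organism (strain Wistar albino) for inhibition, with Rattus norvegicus as the target, read by paw edema, with stated times of 1 h and 3 h, at a dose of 0.32 mmol/kg by the intraperitoneal route (on this read-out lower numbers stand for less inhibition and higher numbers for more inhibition at the one dose given (going by the name of the read-out)), where compound 2 gives 9.61%. Compound 1 `COc1ccc(-c2nn(-c3ccc(Cl)cc3)cc2C(CC(=O)c2ccc(Cl)cc2)C(=O)c2ccc(F)cc2)cc1` gives 37.8%, so compound 2 stands at the lower of the two numbers, separated from compound 1 by the step of a number 28.2 percentage points lower from compound 1 to compound 2 (beyond the scatter). Compound 3 `COc1ccc(C(=O)C(CC(=O)c2ccc(Cl)cc2)c2cn(-c3ccc(S(N)(=O)=O)cc3)nc2-c2ccc(OC)cc2)cc1` differs from compound 2 by sulfamoyl in place of chloro on an aromatic carbon. Within the data shown here, no measured step involves a chloro group leaving or a sulfamoyl group entering, so the single measured step does not bear on this change, and no shift beyond the scatter is expected, the expected step being a number 5.4 percentage points higher from compound 2 to compound 3 (within the scatter). Compound 3 is therefore estimated at 15%, within a range from 0% to 40%.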

Compound 3, a percentage reported as inhibition, in the whole organism at one dose (the size of the read-out at that dose, not a potency): 22.5%
Estimate against measurement, compound 3: 7.5 percentage points below, and the stated range covers the measured number.
By their numbers in this assay, from the lowest: compound 2; then compound 3; then compound 1.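

At this place on the shared core, going from 4-chlorophenyl to 4-sulfamoylphenyl gives, in this assay, a number 12.9 percentage points higher from compound 2 to compound 3 (beyond the scatter). Among these compounds, the one earlier step lay elsewhere in the molecule, so this is the first sign that this place can also move the read-out. Nothing available explains the rise. The compounds shown leave open how an amine or a carboxylic acid at this place would read. They also leave open whether the same swap would give a similar step with the fluoro group of compound 1 in place.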